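Replacing Bromo with Isopropyl: an Expected Shift in Binding

The source may report more compounds than this note shows. Statements on the series, on what has been measured and on what is new or still open speak of the compounds shown alone.

Of the compounds shown here, two sharing one core have been measured in an assay on isolated protein for displacement of a labelled ligand from melanin-concentrating hormone receptor 1 (Homo sapiens); on this read-out higher numbers stand for weaker inhibition and lower numbers for stronger inhibition. Among the measured compounds shown here, compound 1 `CCCc1cc(N)c2cc(NC(=O)/C=C/c3ccc(C(C)(C)C)cc3)ccc2n1` gives 22 nM, while compound 2 `CCCc1cc(N)c2cc(NC(=O)/C=C/c3ccc(Br)cc3)ccc2n1` gives 4 nM, the lowest of the two numbers; the single measured step, a 5.5-fold lower number from compound 1 to compound 2 (0.74 log units; beyond the scatter), was bromo in place of tert-butyl on an aromatic carbon. Compound 3 `CCCc1cc(N)c2cc(NC(=O)/C=C/c3ccc(C(C)C)cc3)ccc2n1` differs from compound 2 by isopropyl in place of bromo on an aromatic carbon. For the measured compounds named here, the only step that bears on this change is the one from compound 1 to compound 2, and it runs the other way: an alkyl group at that place gave the higher number. Since compound 3 carries isopropyl rather than the tert-butyl of compound 1, the return is expected to be partial, so compound 3 is expected to move as a 2.5-fold higher number from compound 2 to compound 3 (0.40 log units; beyond the scatter) in this assay. Compound 3 is therefore estimated at 10 nM, within a range from 4 nM to 25 nM.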

Compound 3, half-maximal inhibitory concentration: 2.9 nM
For compound 3 the middle estimate is 3.4-fold (0.54 log units) above the measured one; the measured number lies below the stated range.
By their numbers in this assay, from the lowest: compounds 3 and 2 (each within the scatter of the next); then compound 1.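

In this assay, the exchange of bromo for isopropyl gives a 1.4-fold lower number from compound 2 to compound 3 (0.14 log units; within the scatter), so these two groups cannot be told apart at this position, and an alkyl group there does not by itself bring a higher number. Among these three compounds, the higher number stays with tert-butyl alone: hydrogen in place of one of its methyl groups gives a 7.6-fold lower number from compound 1 to compound 3 (0.88 log units; beyond the scatter), which places the difference in that single methyl group. The compounds shown offer no evidence on why the numbers fall this way.

From the compounds shown here alone, it remains open whether a group such as an amine, a carboxylic acid or a methoxy group at this position would stay with compound 2 and compound 3 or move towards compound 1. A longer chain such as n-butyl or a cyclopropyl group poses the same question.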